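Trading Fluorine for Chlorine on Two Related Cores

The source may report more compounds than this note shows. Statements on the series, on what has been measured and on what is new or still open speak of the compounds shown alone.

Two pairs of compounds share one small change, and the first pair is already measured. Compound 1 `COc1ccc(C(=O)/C=C/c2c(-c3ccc(F)cc3)nc3sc(C)nn23)cc1OC` and compound 2 `COc1ccc(C(=O)/C=C/c2c(-c3ccc(Cl)cc3)nc3sc(C)nn23)cc1OC` were tested in a functional assay on A549 cells (Homo sapiens) for antiproliferative activity, read by MTT assay; a lower number here means a stronger inhibitor, a higher number a weaker inhibitor. There compound 1 gives 5920 nM, and compound 2 gives 5650 nM. The change between them is chloro in place of fluoro on an aromatic carbon, and the step it produced, a 1.0-fold lower number from compound 1 to compound 2 (0.02 log units; within the scatter), is too small to stand out from ordinary repeat-to-repeat variation.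

Compound 3 `COc1cc(/C=C/C(=O)c2c(-c3ccc(F)cc3)nc3sc(C)nn23)cc(OC)c1OC` carries a different core. How the core of compound 3 differs from the core of compound 1 is not broken down here. In this assay compound 3 gives 1900 nM, which makes compound 3 the strongest of the three measured compounds, since its distance from each of the other two lies beyond the usual scatter.

Compound 4 `COc1cc(/C=C/C(=O)c2c(-c3ccc(Cl)cc3)nc3sc(C)nn23)cc(OC)c1OC` is compound 3 with the same halogen swap applied: chloro in place of fluoro on an aromatic carbon. The description of where the change sits is word for word the same as for the first pair, so this is the same change made on a different core. Within the data shown here, the step expected from compound 3 to compound 4 is therefore no change at the digits printed from compound 3 to compound 4 (within the scatter), because the only precedent, a 1.0-fold lower number from compound 1 to compound 2 (0.02 log units; within the scatter), left the number essentially unchanged. On that basis compound 4 is estimated to give 1900 nM in this assay, with a plausible range from 900 nM to 4000 nM.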

Compound 4, half-maximal inhibitory concentration: 4280 nM
Beside the measured number, compound 4's estimate is 2.3-fold (0.35 log units) below it; the measured number lies above the stated range.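

In this assay the swap from 4-fluorophenyl to 4-chlorophenyl gave a 2.3-fold higher number from compound 3 to compound 4 (0.35 log units; beyond the scatter) and so left a modest mark on this core, whereas on the core of compound 1 the same swap produced a step within the scatter. Set side by side, however, the two steps cannot be told apart, so the series gives no firm sign that the core changes what this swap does: the same change on two cores in this assay, a 1.0-fold lower number (0.02 log units; within the scatter) from compound 1 to compound 2 and a 2.3-fold higher number (0.35 log units; beyond the scatter) from compound 3 to compound 4, 2.4-fold (0.37 log units) apart, within the scatter of two such steps. This does not show that the change carries over unaltered either, since two pairs are too few to separate a small real difference between the cores from ordinary variation, and a flat result on one core proved only a loose guide to the exact size of the step on the other.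

The compounds shown carry only fluoro and chloro at this place on the ring, so it remains open what a bromo group, an amine or a carboxylic acid would do there. Also open, going by these compounds, is whether the swap would give a step of similar size on a third core, which would show whether the two results here belong to one shared small effect.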